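Piperidin-4-yl replaces dimethylaminoethyl on a PLK1 amide

The source may hold more compounds than are shown below. What is called first, only, known or untested is meant among the compounds shown, and "the series" means these compounds.

Measured so far:
compound 1 `COc1cc(C(=O)NC2CCCCC2)ccc1Nc1ncc2c(n1)N(C1CCCC1)[C@H](C)C(=O)N2C`: 160 nM
compound 2 `COc1cc(C(=O)NCCN(C)C)ccc1Nc1ncc2c(n1)N(C1CCCC1)[C@H](C)C(=O)N2C`: 21 nM

Two compounds share one core and differ only at the amide nitrogen. In an assay on isolated protein for inhibition of serine/threonine-protein kinase PLK1 (Homo sapiens), read by Z'-LYTE (a higher number here means a weaker inhibitor, a lower number a stronger inhibitor), compound 1 gives 160 nM and compound 2 gives 21 nM. Among the compounds with values here, compound 2 therefore holds the lowest of the two numbers, and its only neighbour is compound 1, reached by the step of a 7.6-fold lower number from compound 1 to compound 2 (0.88 log units; beyond the scatter).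

Compound 3 `COc1cc(C(=O)NC2CCNCC2)ccc1Nc1ncc2c(n1)N(C1CCCC1)[C@H](C)C(=O)N2C` differs from compound 2 by piperidin-4-yl in place of 2-(dimethylamino)ethyl on an amide-type nitrogen. Within the data shown here, the one measured step at this position, a 7.6-fold lower number from compound 1 to compound 2 (0.88 log units; beyond the scatter), moved from cyclohexyl to 2-(dimethylamino)ethyl and was modest. The present change keeps a group with one hydrogen-bond acceptor on the amide nitrogen and adds one hydrogen-bond donor within a six-membered ring, so for compound 3 the expected step is a 1.1-fold lower number from compound 2 to compound 3 (0.02 log units; within the scatter), within the scatter of this assay. Compound 3 is estimated at 20 nM, with a range from 7 nM to 60 nM.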

Compound 3, half-maximal inhibitory concentration: 9 nM
Compound 3: middle estimate off by 2.2-fold (0.35 log units), on the high side; the measured number falls inside the stated range.
By their numbers in this assay, from the lowest: compound 3; then compound 2; then compound 1.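

With piperidin-4-yl on the amide-type nitrogen, this assay gives the lowest number of the three compounds, and the open 2-(dimethylamino)ethyl chain is not needed to reach it (a 2.3-fold lower number from compound 2 to compound 3 (0.37 log units; beyond the scatter)). The comparison with cyclohexyl is cleaner than the earlier step at this position, which replaced a ring with an open chain: here a six-membered ring stays in place, and the ring with one nitrogen as its hetero atom gives a large change (an 18-fold lower number from compound 1 to compound 3 (1.25 log units; beyond the scatter)). Among these compounds, then, the presence of a ring does not by itself set the number.

The compounds shown leave open whether the number would hold with a piperidine carrying a methyl on its nitrogen, a morpholine or a longer amine chain. No evidence is available that explains these differences.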